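A few compounds are considered here, and "the series" means these few. Any claim that something is new, unique, unknown or untested is made for them only; others in the source may bear on it.

Among the measured compounds shown here, only two compounds with a shared core have numbers so far. In a functional assay on HepG2 cells (Homo sapiens) for antiproliferative activity, read by MTT assay, with a stated time of 72 h (on this read-out higher numbers stand for weaker inhibition and lower numbers for stronger inhibition), compound 1 (`O=C(N/N=C/c1cccn1CCCN1CCCC1)Nc1ccc(Oc2ccnc3[nH]ccc23)c(F)c1`) gives 3500 nM and compound 2 (`CN(C)CCCn1cccc1/C=N/NC(=O)Nc1ccc(Oc2ccnc3[nH]ccc23)cc1`) gives 4190 nM as its reading. Compound 2 therefore stands level with compound 1, since the two values lie within the usual scatter of repeated measurements and cannot be told apart.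

Compound 3 (`O=C(N/N=C/c1cccn1CCCN1CCCC1)Nc1ccc(Oc2ccnc3[nH]ccc23)cc1`) has no number yet. It differs from compound 2 by a single change (pyrrolidin-1-yl in place of dimethylamino on a saturated chain carbon, three bonds along the chain from an aromatic nitrogen), which places pyrrolidin-1-yl where dimethylamino stood, on a saturated chain carbon, three bonds along the chain from an aromatic nitrogen. For the measured compounds named here, no pair of measured compounds shows this change alone, so its size cannot be read directly from the data. The only hint is indirect: compound 2 differs from compound 1 in more than this one place, yet compound 1, which carries 3-(pyrrolidin-1-yl)propyl, gives 3500 nM in this assay as well. The estimated step (a 1.1-fold lower number from compound 2 to compound 3 (0.04 log units; within the scatter)) is expected to stay within the scatter, with no firm direction. The expected value for compound 3 is 3800 nM within an estimated range (1800 nM to 8000 nM).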

Compound 3, half-maximal inhibitory concentration: 1420 nM
Compound 3: the middle estimate sits 2.7-fold (0.43 log units) above what was measured, outside the stated range (below it).
By their numbers in this assay, from the lowest: compound 3; then compounds 1 and 2 (each within the scatter of the next).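

In this assay, the change from dimethylamino to pyrrolidin-1-yl on a saturated chain carbon, three bonds along the chain from an aromatic nitrogen, can now be read directly, and it gives a 3.0-fold lower number from compound 2 to compound 3 (0.47 log units; beyond the scatter). Compound 3 also isolates a second change, hydrogen in place of fluoro on an aromatic carbon, which gives a 2.5-fold lower number from compound 1 to compound 3 (0.39 log units; beyond the scatter). The level readings of compound 1 and compound 2 could not reveal either step, since those two compounds differ in both places at once, and no measurement here offers a reason for either step.

The compounds shown cover only dimethylamino and pyrrolidin-1-yl at the chain end, so it remains open whether a piperidine, a morpholine or a longer chain would follow the step seen with pyrrolidin-1-yl. Among the compounds shown here, with fluoro the only group compared against hydrogen on the aromatic carbon, it also remains open how chloro or methoxy would read there, and whether the step from fluoro to hydrogen would be the same with dimethylamino at the chain end.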